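Oxadiazole for thiadiazole in a hydroxy-azole amide pair

The source may hold more compounds than are shown below. What is called first, only, known or untested is meant among the compounds shown, and "the series" means these compounds.

compound 1 `O=C(Nc1cc(C(F)(F)F)cc(C(F)(F)F)c1)c1nsnc1O`: > 100000 nM
compound 2 `O=C(Nc1cccc(C(F)(F)F)c1)c1nsnc1O`: > 100000 nM

In an assay on isolated protein for inhibition of mitogen-activated protein kinase kinase kinase 14 (Homo sapiens), read by ADP-Glo, with a stated time of 60 min, in the presence of a further agent that is not named here (a lower number here means a stronger inhibitor, a higher number a weaker inhibitor), compound 2 returns only a limit, > 100000 nM, and so stands at the edge of what the assay reports. Compound 1 likewise gives a limit, > 100000 nM. Among the measured compounds shown here, the single measured step, a step that the two limits leave unreadable from compound 1 to compound 2, is therefore unreadable; the limit of > 100000 nM in this assay, at which 2 of the 2 values shown sit, covers both values. Compound 3 `O=C(Nc1cccc(C(F)(F)F)c1)c1nonc1O` differs from compound 2 by a group of 6 heavy atoms (2 carbon, 2 nitrogen, 2 oxygen; one five-membered aromatic ring with 3 hetero atoms) in place of a group of 6 heavy atoms (2 carbon, 2 nitrogen, 1 oxygen, 1 sulfur; one five-membered aromatic ring with 3 hetero atoms), on a carbonyl carbon. For the measured compounds named here, no measured step bears on this ring exchange. Compound 3 is expected to reach only the limit as well, estimated at 150000 nM within 30000 nM to 1000000 nM. Going by the values given here, this expected change, a step that the limit leaves unreadable from compound 2 to compound 3, is anchored by no measured step.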

Compound 3, half-maximal inhibitory concentration: > 100000 nM
Compound 3 was reported as a limit (the forecaster's own chance of this, stated with the estimate: 85%); the middle value is on the limit's open side.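

In this assay, among the compounds shown here, compound 3 gives the limit > 100000 nM and so no step from compound 2 to compound 3 can be read: the limit of > 100000 nM in this assay, at which 3 of the 3 values shown sit. The compounds shown leave open whether the 4-hydroxy-1,2,5-oxadiazol-3-yl group differs at all from the ring it replaces, since none of them gives a value short of the limit.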